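A Hydroxy Group on the Pyrrolidine of Compound 3

The source may hold more compounds than are shown below. What is called first, only, known or untested is meant among the compounds shown, and "the series" means these compounds.

Of the compounds shown here, three have been measured in a functional assay for antagonist activity at melanin-concentrating hormone receptor 1 (Homo sapiens); a lower number here means a stronger inhibitor, a higher number a weaker inhibitor. Compound 1 `N#Cc1cccc([C@]23CC[C@@H](N(CCCN4CC[C@@H](O)C4)C(=O)Nc4ccc(F)c(Cl)c4)[C@H]2C3)c1` gives 22 nM, compound 2 `NCc1cnc([C@]23CC[C@@H](N(CCN4CCCC4)C(=O)Nc4ccc(F)c(C(F)(F)F)c4)CC2C3)s1` gives 431 nM, and compound 3 `NCc1ncc([C@]23CC[C@@H](N(CCN4CCCC4)C(=O)Nc4ccc(F)c(C(F)(F)F)c4)C2C3)s1` gives 107 nM. Compound 3 thus stands second highest of the three numbers: its nearest neighbour is compound 2, whose number is higher by a margin beyond the scatter, and the furthest is compound 1, whose number is lower, again beyond the scatter. No pair among these three differs in a single place, so no step between measured compounds is available.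

Compound 4 `NCc1ncc([C@]23CC[C@@H](N(CCN4CC[C@H](O)C4)C(=O)Nc4ccc(F)c(C(F)(F)F)c4)C2C3)s1` is not yet measured. It differs from compound 3 by hydroxy in place of hydrogen on a saturated ring carbon, a hydroxy in place of hydrogen on a saturated ring carbon. Going by the values given here, with no measured step of this kind to draw on, the change is expected to move the number only modestly, if at all, most likely within or just beyond the scatter, in the direction of a lower number. The expected step of a 1.3-fold lower number from compound 3 to compound 4 (0.13 log units; within the scatter) is therefore small. Compound 4 is estimated at 80 nM in this assay, with a range from 30 nM to 250 nM.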

Compound 4, inhibition constant: 99 nM
Compound 4: the middle estimate sits 1.2-fold (0.09 log units) below what was measured; the range from low to high includes it.
By their numbers in this assay, from the lowest: compound 1; then compounds 4 and 3 (each within the scatter of the next); then compound 2.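

Going by these compounds alone, this pair gives the first comparison in the set that differs in one place only. In this assay the change from pyrrolidin-1-yl to 3-hydroxypyrrolidin-1-yl gives a 1.1-fold lower number from compound 3 to compound 4 (0.03 log units; within the scatter) and so shows no readable effect: at this saturated ring carbon, two ring bonds from the ring nitrogen, a hydroxy in place of hydrogen leaves the number where it was on this core. No measurement is available that would explain this result.

On these data alone, whether a methoxy, an amine or a carboxylic acid at this ring carbon would leave the number equally unmoved remains open. Also open, as far as these compounds go, is what the hydroxy contributes in compound 1, which has a longer chain and differs from compound 4 in more than one place.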